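A Thiazole Amide Replacing a Trifluoromethylphenyl Amide

A few compounds are considered here, and "the series" means these few. Any claim that something is new, unique, unknown or untested is made for them only; others in the source may bear on it.

Compound 3 `O=C(Nc1ccc(Cl)cc1CN1C(=O)c2ccccc2C1=O)c1ccccc1C(F)(F)F` is known in an assay on CHO cells for positive allosteric modulation of metabotropic glutamate receptor 5 (Rattus norvegicus), read by FLIPR (on this read-out lower numbers stand for an effect already at smaller amounts and higher numbers for an effect only at larger amounts of compound), only by a limit: compound 3 gives < 1000 nM, which is a limit of the assay and not a number. Its two neighbours stand the same way. Compound 1 `O=C(Nc1ccc(Cl)cc1CN1C(=O)c2ccccc2C1=O)c1cccnc1` gives < 1000 nM in this assay, a limit. Compound 2 `O=C(Nc1ccc(Cl)cc1CN1C(=O)c2ccccc2C1=O)c1ccccc1` gives < 1000 nM, again a limit. The steps between them, a step that the two limits leave unreadable from compound 1 to compound 2, a step that the two limits leave unreadable from compound 1 to compound 3 and a step that the two limits leave unreadable from compound 2 to compound 3, cannot be sized, since all three values sit at the limit of < 1000 nM in this assay, at which 3 of the 3 values shown sit.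

Compound 4 `O=C(Nc1ccc(Cl)cc1CN1C(=O)c2ccccc2C1=O)c1cncs1` differs from compound 3 in one place: 1,3-thiazol-5-yl in place of 2-(trifluoromethyl)phenyl on a carbonyl carbon. Within the data shown here, no measured step bears a readable size on this change, as the group on the carbonyl carbon has already been exchanged twice among compounds 1, 2 and 3 without any value leaving the limit. The step is therefore expected to be a step that the limit leaves unreadable from compound 3 to compound 4, that is, nothing beyond the scatter. Compound 4 is expected to give about 300 nM, between 50 nM and 2000 nM, and quite possibly again only a limit.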

Compound 4, half-maximal effective concentration: < 1000 nM
Compound 4 gave a limit, no number (the forecaster's own chance of this, stated with the estimate: 60%); the middle value does not contradict the limit.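

The steps linking compound 4 to compound 1, compound 2 and compound 3 cannot be read in this assay, as none of the four compounds has a number, only a limit: the limit of < 1000 nM in this assay, at which 4 of the 4 values shown sit.

The compounds shown leave open whether exchanging the group on the carbonyl carbon changes the value at all.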